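Coumarin ether series: amine variation and aryl piperazine

The source may report more compounds than this note shows. Statements on the series, on what has been measured and on what is new or still open speak of the compounds shown alone.

Measured so far in a functional assay on ileum for antagonist activity at histamine H1 receptor (Cavia porcellus), tested at 1 mg/mL; on this read-out higher numbers stand for an effect only at larger amounts of compound and lower numbers for an effect already at smaller amounts:
compound 1 `Cc1cc(=O)oc2ccc(OCC(O)CN3CCCCC3)cc12`, 0.0083 ug/mL
compound 2 `CCCNCC(O)COc1ccc2c(-c3ccccc3)cc(=O)oc2c1`, 0.0085 ug/mL
compound 3 `O=c1cc(-c2ccccc2)c2ccc(OCC(O)CN3CCNCC3)cc2o1`, 0.0086 ug/mL

The three measured compounds share the same side chain and differ only in the amine at its end. In this assay, going by the values given here, the number of compound 3 0.0086 ug/mL and the number of compound 1 0.0083 ug/mL lie within the usual scatter of each other, and the single one-place step, a 1.0-fold higher number from compound 2 to compound 3 (0.01 log units; within the scatter), is also within the scatter. Among the compounds with values here, nothing measured so far separates these amines.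

Compound 4 `COc1ccccc1N1CCN(CC(O)COc2ccc3c(-c4ccccc4)cc(=O)oc3c2)CC1` differs from compound 3 by 2-methoxyphenyl in place of hydrogen on an amine nitrogen in a ring. Within the data shown here, no measured step bears directly on a substituent of this kind on the ring nitrogen; the only step available, from a propylamino group to a piperazinyl group, was within the scatter. With no evidence for an effect of the amine terminus, the expectation for compound 4 is a number close to that of compound 3, a step of a 1.0-fold higher number from compound 3 to compound 4 (0.02 log units; within the scatter) not beyond the scatter, with the range widened for the absence of a direct precedent. The estimate for compound 4 is 0.009 ug/mL, expected between 0.003 ug/mL and 0.03 ug/mL.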

Compound 4, half-maximal effective concentration: 0.0089 ug/mL
Compound 4: middle estimate off by 1.0-fold (0.00 log units), on the high side; the measured number falls inside the stated range.
By their numbers in this assay, from the lowest: compounds 1, 2, 3 and 4 (each within the scatter of the next).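

In this assay, 2-methoxyphenyl in place of hydrogen on the amine nitrogen in the ring gives a 1.0-fold higher number from compound 3 to compound 4 (0.01 log units; within the scatter). The earlier step, a 1.0-fold higher number from compound 2 to compound 3 (0.01 log units; within the scatter), only exchanged one amine for another, whereas this one shows that the ring nitrogen can carry a group of 8 heavy atoms, including a six-membered aromatic ring of carbon only, with no change beyond the scatter. Nothing available accounts for this insensitivity to the added group.

As far as these compounds go, whether an unsubstituted phenyl, a benzyl or a carboxylic acid on this ring nitrogen would move the number beyond the scatter stays open. Also open, from the compounds shown here alone, is what a longer chain between the ether oxygen and the amine, or a chain without the hydroxyl group, would do to the number.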